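The compounds below may be only part of what the source reports. "The series", "measured", "known", "first", "only" and "open" are said of these compounds alone.

Measured in a functional assay on the whole organism (strain Wistar) for inhibition, with Rattus norvegicus as the target, read by paw edema, with stated times of 60 min and 6 h, at a dose of 100 mg/kg by the oral route; a higher number here means more inhibition at the dose given (going by the name of the read-out), a lower number less inhibition:
Compound 1 `COc1cc2c(cc1OC)C(CC(N)=O)CC2`: 27.8%
Compound 2 `CCCCNC(=O)CC1CCc2cc(OC)c(OC)cc21`: 24.1%
Compound 3 `CCCCCCNC(=O)CC1CCc2cc(OC)c(OC)cc21`: 38.3%

Compound 3 gives the highest number of the three in this assay; compound 1 sits a number 10.5 percentage points higher from compound 1 to compound 3 (beyond the scatter) and compound 2 a number 14.2 percentage points higher from compound 2 to compound 3 (beyond the scatter). Compound 4 `COc1cc2c(cc1OC)C(CC(=O)NC1CCCC1)CC2` differs from compound 3 by cyclopentyl in place of hexyl on an amide-type nitrogen. The steps on this nitrogen bear on it: a number 3.7 percentage points lower from compound 1 to compound 2 (within the scatter) was within the scatter, while a number 10.5 percentage points higher from compound 1 to compound 3 (beyond the scatter) and a number 14.2 percentage points higher from compound 2 to compound 3 (beyond the scatter) were modest gains. Cyclopentyl, with five carbons, falls between butyl and hexyl in size, so compound 4 is expected to show a small loss from compound 3, a number 8.3 percentage points lower from compound 3 to compound 4 (within the scatter), and in this assay compound 4 is estimated at 30%, between 18% and 42%.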

Compound 4, a percentage reported as inhibition, in the whole organism at one dose (the size of the read-out at that dose, not a potency): 40.7%
For compound 4 the middle estimate is 10.7 percentage points below the measured one; the range from low to high includes it.
By their numbers in this assay, from the lowest: compounds 2 and 1 (each within the scatter of the next); then compounds 3 and 4 (each within the scatter of the next).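

In this assay, a number 2.4 percentage points higher from compound 3 to compound 4 (within the scatter) is a step that leaves the two compounds level, so on this amide-type nitrogen a five-membered ring of carbon does as well as the open hexyl chain. Cyclopentyl also stands clear of butyl and of hydrogen on the same nitrogen, with a number 16.6 percentage points higher from compound 2 to compound 4 (beyond the scatter) and a number 12.9 percentage points higher from compound 1 to compound 4 (beyond the scatter) as modest gains, so a gain here does not depend on an open chain of hexyl length. The compounds shown leave open how cyclohexyl, benzyl or a hexyl chain ending in an amine would fare on this nitrogen. Nothing measured alongside these numbers accounts for the steps.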